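A few compounds are considered here, and "the series" means these few. Any claim that something is new, unique, unknown or untested is made for them only; others in the source may bear on it.

In an assay on HeLa cells with Bile acid receptor (Homo sapiens) as the target, read by a luciferase reporter, with a stated time of 24 h (a lower number here means that less compound is needed, a higher number that more compound is needed for the effect), compound 1 `CC(C)Oc1ccc(CNC(=O)c2ccc(C(C)(C)C)cc2)cc1` gives 170 nM, and compound 2 `CSc1ccc(CNC(=O)c2ccc(C(C)(C)C)cc2)cc1` gives 100 nM; the step of a 1.7-fold lower number from compound 1 to compound 2 (0.23 log units; within the scatter) separates them, so compound 2 stands at a number that compound 1 matches within the scatter. Compound 3 `CC(C)(C)c1ccc(C(=O)NCc2ccc(SC(F)(F)F)cc2)cc1` differs from compound 2 by trifluoromethyl in place of methyl on a sulfur. Among the measured compounds shown here, no measured step touches this sulfur substituent; the only step known, a 1.7-fold lower number from compound 1 to compound 2 (0.23 log units; within the scatter), concerns the group on the aromatic carbon and stays within the scatter, so a change beyond the scatter in this assay is not expected. Compound 3 is therefore estimated at 100 nM, between 40 nM and 250 nM, an expected step of no change at the digits printed from compound 2 to compound 3 (within the scatter).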

Compound 3, half-maximal effective concentration: 0.4 nM
For compound 3 the middle estimate is 250-fold (2.40 log units) above the measured one; measured number below the stated range.
By their numbers in this assay, from the lowest: compound 3; then compounds 2 and 1 (each within the scatter of the next).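

In this assay, the group on the sulfur proves to be a far stronger lever than the earlier pair could show: trifluoromethyl in place of methyl brings a 250-fold lower number from compound 2 to compound 3 (2.40 log units; beyond the scatter) and so moves well beyond the scatter. Replacing isopropoxy with (trifluoromethyl)sulfanyl on the aromatic carbon likewise brings a 430-fold lower number from compound 1 to compound 3 (2.63 log units; beyond the scatter), whereas methylsulfanyl in that place did not move the number beyond the scatter. Nothing available accounts for the size of this step. Going by these compounds, it remains open whether the sulfur itself is needed, which trifluoromethoxy on the same aromatic carbon would test. Also open, on these data alone, is whether ethyl or difluoromethyl on the sulfur would fall nearer compound 2 or compound 3.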